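From a methoxyphenyl urea to a methylphenyl urea

The source may hold more compounds than are shown below. What is called first, only, known or untested is meant among the compounds shown, and "the series" means these compounds.

The three measured compounds share one core and differ only at the aryl end of the urea. Compound 1 `CC1(C)CC(NC(=O)Nc2ccccc2)c2cc(Cl)ccc2O1` carries an unsubstituted phenyl, and in a functional assay (aorta) with Rattus norvegicus as the target (on this read-out higher numbers stand for an effect only at larger amounts of compound and lower numbers for an effect already at smaller amounts), compound 1 gives 7800 nM. Compound 2 `COc1cccc(NC(=O)NC2CC(C)(C)Oc3ccc(Cl)cc32)c1` carries a 3-methoxyphenyl; in this assay compound 2 reaches only a limit, > 10000 nM. Compound 3 `COc1ccc(NC(=O)NC2CC(C)(C)Oc3ccc(Cl)cc32)cc1` carries a 4-methoxyphenyl; in this assay compound 3 also stands at a limit, > 30000 nM. Compound 3 is thus the least precisely placed of the three: the step of an at least 3.8-fold higher number from compound 1 to compound 3 (0.58 log units; beyond the scatter) is clear, the step of an at least 1.2-fold higher number from compound 1 to compound 2 (0.10 log units; that floor lies within the scatter) is smaller, and the difference a step that the two limits leave unreadable from compound 2 to compound 3 cannot be sized because both ends rest on limits (the limit of > 10000 nM in this assay, at which 1 of the 3 values shown sits, and (the limit of > 30000 nM in this assay, at which 1 of the 3 values shown sits)).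

Compound 4 `Cc1ccccc1NC(=O)NC1CC(C)(C)Oc2ccc(Cl)cc21` differs from compound 3 in that (2-methylphenyl in place of 4-methoxyphenyl on an amide-type nitrogen). The step that bears on this change is the one from the plain phenyl to compound 3, because the methoxy cost an at least 3.8-fold higher number from compound 1 to compound 3 (0.58 log units; beyond the scatter); removing it should undo at least that rise. Nothing measured shows what the entering 2-methylphenyl adds. Compound 4 is therefore expected to land near the position of the unsubstituted compound. Compound 4 is estimated at 8000 nM, between 2000 nM and 30000 nM, which is expected to mean an at least 3.7-fold lower number from compound 3 to compound 4 (0.57 log units; beyond the scatter).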

Compound 4, half-maximal effective concentration: > 10000 nM
Compound 4: a limit, no number; the forecaster's own chance of this, stated with the estimate: 35%; middle value at least 1.2-fold (0.09 log units) away from the limit.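

In this assay compound 4 stands at a limit, > 10000 nM, so replacing the 4-methoxyphenyl with a 2-methylphenyl at this amide-type nitrogen yields no number. The absence of a measured number is therefore not confined to the two methoxyphenyl ureas: among the four compounds, only the plain phenyl of compound 1 gives one. The one readable step, an at least 1.2-fold higher number from compound 1 to compound 4 (0.10 log units; that floor lies within the scatter), rests on a floor, so it neither separates the 2-methylphenyl from the plain phenyl nor places the two together; the steps to the two methoxyphenyl compounds cannot be read, and compound 4 shares its limit with compound 2: the limit of > 10000 nM in this assay, at which 2 of the 4 values shown sit.

The compounds shown leave open how far compound 4 actually lies from compound 1, and whether any group on this phenyl would leave the read-out without a number or only the methoxy and methyl groups seen here. Nor do they show what a phenyl carrying a chlorine, a nitrile or an amine in place of the methyl would give in this assay.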